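The compounds below may be only part of what the source reports. "The series", "measured", "known", "first", "only" and "open" are said of these compounds alone.

Compound 1 `Cc1cc(C(=O)NCN2CCC(c3cccc[n+]3[O-])CC2)ccc1F`: 67%
Compound 2 `O=C(CN1CCC(c2ccccn2)CC1)Nc1c(Cl)cc(Cl)cc1Cl`: 45%
Compound 3 `O=C(CN1CCC(c2cccc[n+]2[O-])CC1)NC1CCCCC1`: 58%

In a functional assay on HEK293 cells for agonist activity at D(4) dopamine receptor (Homo sapiens), read by FLIPR (a higher number here means a larger maximal response, a lower number a smaller maximal response), compound 3 gives 58%, the second highest of the three numbers. Compound 1 gives 67%, a number that lies within the usual scatter of compound 3, so no order can be drawn between them. Compound 2 gives 45%, a number that lies beyond the scatter below compound 3.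

Compound 4 `Cc1ccc(Cl)cc1NC(=O)CN1CCC(c2cccc[n+]2[O-])CC1` differs from compound 3 by 5-chloro-2-methylphenyl in place of cyclohexyl on an amide-type nitrogen. Within the data shown here, no pair of measured compounds shows this change, so its effect is unknown from the data. The aromatic ring of compound 2 accompanies the lowest number, so a small downward step is expected, a number 8 percentage points lower from compound 3 to compound 4 (within the scatter), of a size not clearly beyond the scatter. In this assay compound 4 is expected to give about 50%, within a range from 35% to 65%.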

Compound 4, largest response reached (reported as efficacy), in percent of the reference or control that the assay uses: 58%
Compound 4: the middle estimate sits 8 percentage points below what was measured; the measured number falls inside the stated range.
By their numbers in this assay, from the lowest: compound 2; then compounds 3, 4 and 1 (each within the scatter of the next).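

In this assay putting 5-chloro-2-methylphenyl in place of cyclohexyl on an amide-type nitrogen gives no change at the digits printed from compound 3 to compound 4 (within the scatter) and so shows that this position can carry an aromatic ring as well as a non-aromatic one with the response kept. The earlier compounds shown here held no pair that differed only here. Nothing measured offers a reason for this. Still open, going by these compounds, is whether plain phenyl, without the chlorine and the methyl, would behave the same way. A ring bearing an amine or a carboxylic acid at this nitrogen also remains untested in the compounds shown.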